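This account rests on a few compounds, and the source may have more. Where it says the series, first, only, none or still open, it means among the compounds named here.

Compound 1, `CN(C)CCn1cnnc1-c1cc(Oc2ccc(NC(=O)N/N=C/c3ccc(Cl)cc3Cl)cc2F)ccn1`, gives 810 nM in a functional assay on A549 cells (Homo sapiens) for cytotoxicity, read by MTT assay, with a stated time of 72 h; a lower number here means a stronger inhibitor, a higher number a weaker inhibitor. Compound 2, `CN(C)CCn1cnnc1-c1cc(Oc2ccc(NC(=O)N/N=C/c3ccccc3O[N+](=O)[O-])cc2F)ccn1`, gives 1200 nM in this assay. Replacing the 2,4-dichlorophenyl by the 2-(nitrooxy)phenyl on the carbon with a double bond to nitrogen is accompanied by a 1.5-fold higher number from compound 1 to compound 2 (0.17 log units; within the scatter). Within the data shown here, of the two numbers so far, that of compound 2 is the higher, but compound 1 sits within the scatter of it, so the two are not distinguishable. Compound 3, `COc1cc(/C=N/NC(=O)Nc2ccc(Oc3ccnc(-c4nncn4CCN(C)C)c3)c(F)c2)cc(OC)c1OC`, carries 3,4,5-trimethoxyphenyl in place of 2-(nitrooxy)phenyl on a carbon with a double bond to nitrogen. Among the measured compounds shown here, the only measured step at this carbon, a 1.5-fold higher number from compound 1 to compound 2 (0.17 log units; within the scatter), stayed within the scatter, and no measured compound carries a trimethoxyphenyl there. On that basis no step beyond the scatter is expected, although the range must stay wide, and the expected step is a 1.3-fold higher number from compound 2 to compound 3 (0.10 log units; within the scatter). Compound 3 is therefore estimated to give 1500 nM in this assay, with a range from 500 nM to 4500 nM.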

Compound 3, half-maximal inhibitory concentration: > 100000 nM
Compound 3: only a limit was reported (the forecaster's own chance of this, stated with the estimate: 5%); at least 66-fold (1.82 log units) between middle value and limit.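

Compound 1 and compound 2 had suggested that the carbon with a double bond to nitrogen accepts a change of aryl group with little effect, but the 3,4,5-trimethoxyphenyl shows that it does not accept every one: an at least 83-fold higher number from compound 2 to compound 3 (1.92 log units; beyond the scatter), and an at least 120-fold higher number from compound 1 to compound 3 (2.09 log units; beyond the scatter). Among these compounds, the 2,4-dichlorophenyl and 2-(nitrooxy)phenyl lie within the scatter of each other, while the 3,4,5-trimethoxyphenyl stands far from both. In this assay, compound 3 gives > 100000 nM, which is a limit of the assay and not a number, so the full size of both steps stays unknown: the limit of > 100000 nM in this assay, at which 1 of the 3 values shown sits.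

The compounds shown leave open whether a single methoxy group, as in 4-methoxyphenyl, or a pair, as in 3,5-dimethoxyphenyl, would go with the same loss. As far as these compounds go, how an unsubstituted phenyl would behave on this carbon also remains open.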